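A few compounds are considered here, and "the series" means these few. Any claim that something is new, unique, unknown or untested is made for them only; others in the source may bear on it.

The measured compounds in a functional assay on SK-OV-3 cells (Homo sapiens) for inhibition, read by sulforhodamine B assay, with a stated time of 48 h; on this read-out higher numbers stand for weaker inhibition of growth and lower numbers for stronger inhibition of growth:

Compound 1 `N=C(N)c1ccc(-c2ccc(-c3cc(Cl)cc(Cl)c3)s2)cc1`: 454 nM
Compound 2 `N=C(N)c1ccc(-c2ccc(-c3ccc(Cl)cc3)s2)cc1F`: 1140 nM
Compound 3 `COc1cc(OC)cc(-c2ccc(-c3ccc(C(=N)N)c(F)c3)s2)c1`: 1640 nM

Among these three numbers, compound 2 gives the second highest. Compound 3 lies nearest to it, and the gap between them is within the scatter, so nothing separates the two. Compound 1 lies furthest from compound 2, with a lower number, and that gap is beyond the scatter.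

Compound 4 `N=C(N)c1ccc(-c2ccc(-c3ccccc3)s2)cc1F` has not yet been measured in this assay. It differs from compound 2 in one place: hydrogen in place of chloro on an aromatic carbon. For the measured compounds named here, no pair of measured compounds shares this change, so there is no measured step to lean on, and the expectation rests on the change alone. A change of this kind is expected to weaken growth inhibition somewhat, giving a higher number, with a step that is expected to sit around the edge of the scatter rather than far beyond it.

For compound 4 the estimate in this assay is 1900 nM, with a range from 800 nM to 4500 nM. This estimate means an expected step of a 1.7-fold higher number from compound 2 to compound 4 (0.22 log units; within the scatter).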

Compound 4, concentration for 50% growth inhibition: 10200 nM
For compound 4 the middle estimate is 5.4-fold (0.73 log units) below the measured one; the measured number lies above the stated range.
By their numbers in this assay, from the lowest: compound 1; then compounds 2 and 3 (each within the scatter of the next); then compound 4.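

In this assay, the change from 4-chlorophenyl to phenyl gives an 8.9-fold higher number from compound 2 to compound 4 (0.95 log units; beyond the scatter), a step beyond the scatter. The earlier compounds shown here differ from one another in more than one place, so they could not isolate this position; this pair shows that, with the rest of compound 2 unchanged, growth inhibition in this assay depends strongly on the chloro para to a large group. Nothing shown here explains why the loss of this one atom has so large an effect.

From the compounds shown here alone, whether a group such as methyl, methoxy or an amine at this place would keep the inhibition seen with chloro remains open. Going by these compounds, the step also rests on a single pair, so it is unknown whether a step of this size would recur in other compounds.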